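Cyclobutyl gives way to a hydroxylated chain

A few compounds are considered here, and "the series" means these few. Any claim that something is new, unique, unknown or untested is made for them only; others in the source may bear on it.

Of the compounds shown here, three have so far been measured in a functional assay on CHO cells for agonist activity at 5-hydroxytryptamine receptor 4 (Homo sapiens), read by a luciferase reporter and cAMP accumulation, with a stated time of 4 h; a lower number here means a smaller maximal response, a higher number a larger maximal response. Compound 1 `CC(C)c1nc(C(=O)NCC2CCN(C3CCC3)CC2)c2ccccn12` gives 20%. Compound 2 `CC(C)c1nc(C(=O)NC2CCN(CC3(O)CCOCC3)CC2)c2ccccn12` gives 72%. Compound 3 `CC(C)c1nc(C(=O)NC[C@@H]2[C@H]3CN(C4CCC4)C[C@@H]23)c2ccccn12` carries the same cyclobutyl group as compound 1 but on an amine within a fused two-ring system; compound 3 gives 59%. Among the three numbers compound 3 stands second highest: its nearest neighbour is compound 2, whose number lies higher by more than the usual scatter, while compound 1 lies farthest from it, well below compound 3.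

Compound 4 `CC(C)c1nc(C(=O)NC[C@@H]2[C@H]3CN(CC(C)(C)CO)C[C@@H]23)c2ccccn12` has not yet been measured. It differs from compound 3 in one place: 2-(hydroxymethyl)-2-methylpropyl in place of cyclobutyl on an amine nitrogen in a ring. Among the measured compounds shown here, no two measured compounds differ in exactly one place, so no measured step maps directly onto this change. For the measured compounds named here, what the numbers do show is that compound 2, the one compound without a cyclobutyl group, reaches the highest value, while compound 1 and compound 3, both with cyclobutyl, sit below it. On that basis the step is expected to be modest and upward, a number 11 percentage points higher from compound 3 to compound 4 (beyond the scatter). Compound 4 is accordingly estimated to give 70% in this assay, with a range from 50% to 90%.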

Compound 4, largest response reached (Emax), in percent of the reference or control that the assay uses: 40%
Compound 4: the middle estimate sits 30 percentage points above what was measured; the measured number lies below the stated range.
By their numbers in this assay, from the lowest: compound 1; then compound 4; then compound 3; then compound 2.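

Among the compounds shown here, at the amine nitrogen in the five-membered ring of the fused system, replacing cyclobutyl with 2-(hydroxymethyl)-2-methylpropyl gives the first reading of a single change in this assay: the swap produces a number 19 percentage points lower from compound 3 to compound 4 (beyond the scatter) on an otherwise unchanged structure. This position therefore responds to the group it carries, and here the open chain with its hydroxyl, which brings one hydrogen-bond donor and one acceptor that cyclobutyl lacks, goes with the smaller maximal response, although compound 4 still reaches 40% in this read-out. Nothing available explains why the response falls with this swap.

The change alters several things at once, so these compounds do not separate the loss of the four-membered ring from the arrival of the hydroxyl; a 2,2-dimethylpropyl group, which keeps the branched chain without the oxygen, would bear directly on that. Going by these compounds, it also stays open how a shorter 2-hydroxyethyl chain, a methoxy-ended chain or a carboxylic acid at the end of the chain would behave at this nitrogen.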